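Losing the Chloro Group at the High End

This account rests on a few compounds, and the source may have more. Where it says the series, first, only, none or still open, it means among the compounds named here.

In a functional assay on MCF7 cells (Homo sapiens) for antiproliferative activity, read by MTT assay, with a stated time of 72 h (a higher number here means a weaker inhibitor, a lower number a stronger inhibitor), compound 3 (`O=C1C=C(N2CCC(c3ccc(Cl)cc3)CC2)C(=O)c2c(O)cccc21`) gives 20500 nM as the highest of three measured numbers. Lower numbers belong to compound 1 (`Cc1ccccc1N1CCN(C2=CC(=O)c3cccc(O)c3C2=O)CC1`) at 9700 nM and compound 2 (`O=C1C=C(N2CCC(c3ccccc3)CC2)C(=O)c2c(O)cccc21`) at 8800 nM by comparison. Compound 4 (`Cc1ccccc1C1CCN(C2=CC(=O)c3cccc(O)c3C2=O)CC1`) has 2-methylphenyl in place of 4-chlorophenyl on a saturated ring carbon. Among the measured compounds shown here, the one measured step bearing on this is a 2.3-fold higher number from compound 2 to compound 3 (0.37 log units; beyond the scatter) (modest, beyond the scatter), where chloro took the place of hydrogen on an aromatic carbon. Compound 1 also carries 2-methylphenyl, though on a different ring. A modest step is therefore expected, estimated as a 2.1-fold lower number from compound 3 to compound 4 (0.31 log units; beyond the scatter) (toward a lower number). The expected value for compound 4 is 10000 nM (estimated range 5000 nM to 20000 nM).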

Compound 4, half-maximal inhibitory concentration: 8900 nM
For compound 4 the middle estimate is 1.1-fold (0.05 log units) above the measured one, within the range that was stated.
By their numbers in this assay, from the lowest: compounds 2, 4 and 1 (each within the scatter of the next); then compound 3.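

In this assay the change to 2-methylphenyl on the saturated ring carbon gives a 2.3-fold lower number from compound 3 to compound 4 (0.36 log units; beyond the scatter) and so removes the penalty seen with 4-chlorophenyl. An added methyl group gives a 1.0-fold higher number from compound 2 to compound 4 (0.00 log units; within the scatter) and leaves the number unchanged within the scatter, whereas chloro gave a 2.3-fold higher number from compound 2 to compound 3 (0.37 log units; beyond the scatter) in the step measured earlier. Nothing measured here explains this difference.

Still open is whether the group or its place on the phenyl ring decides the outcome, as 2-chlorophenyl and 4-methylphenyl are absent from the compounds shown. Going by these compounds, how an amine or a carboxylic acid on that ring would read also remains open.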